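Swapping Morpholine for Pyrrolidine on a Thiosemicarbazone Amidine

The source may hold more compounds than are shown below. What is called first, only, known or untested is meant among the compounds shown, and "the series" means these compounds.

Of the compounds shown here, three sharing one core have been measured in a functional assay on HeLa cells (Homo sapiens) for cytotoxicity, read by MTT assay, with a stated time of 72 h, tested at 10 uM; a higher number here means more inhibition of growth at the concentration tested, a lower number less inhibition of growth. Compound 1 `N/C(=N\NC(=S)N1CCOCC1)c1ccccn1` gives 56.3%. Compound 2 `Cc1ccnc(/C(N)=N/NC(=S)N2CCOCC2)c1` gives 49.1%, the lowest of the three numbers, though its gap to compound 1 is within the scatter, as a number 7.2 percentage points lower from compound 1 to compound 2 (within the scatter) shows for methyl in place of hydrogen on an aromatic carbon. Among the measured compounds shown here, compound 3 `Cc1cccc(/C(N)=N/NC(=S)N2CCCCCC2)n1` gives 71.7%, which lies beyond the scatter above compound 2; compound 3 differs from compound 2 in two places at once, so no single step is counted for that pair.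

Compound 4 `Cc1ccnc(/C(N)=N/NC(=S)N2CCCC2)c1` is not yet measured. It arises from compound 2 by pyrrolidin-1-yl in place of morpholin-4-yl on a thiocarbonyl carbon. For the measured compounds named here, none of the measured steps changes this part of the molecule, so there is no direct guide. Going by the values given here, the only hint is that compound 3, which carries a different ring on the thiocarbonyl carbon, shows the highest number of the three, at 71.7%. On that thin basis a modest rise is expected, with a number 7.9 percentage points higher from compound 2 to compound 4 (within the scatter) as the estimated step, and a wide range. Compound 4 is therefore expected to give about 57% in this assay, between 40% and 74%.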

Compound 4, percent growth inhibition at one concentration: 67%
For compound 4 the middle estimate is 10 percentage points below the measured one; the range from low to high includes it.
By their numbers in this assay, from the lowest: compounds 2 and 1 (each within the scatter of the next); then compounds 4 and 3 (each within the scatter of the next).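

In this assay, among the compounds shown here, pyrrolidin-1-yl in place of morpholin-4-yl on a thiocarbonyl carbon gives a number 17.9 percentage points higher from compound 2 to compound 4 (beyond the scatter), the first reading of a single change at this position. For the compounds shown here, it also shows that this position can move the number by more than the scatter, which the only earlier step, the added methyl on an aromatic carbon, did not do with a number 7.2 percentage points lower from compound 1 to compound 2 (within the scatter). The swap changes two things at once, since the ring goes from six-membered to five-membered and its oxygen is lost, and nothing available here explains why the number rises.

A piperidin-1-yl group on the thiocarbonyl carbon would keep the six-membered ring of morpholin-4-yl without the oxygen, so it could show whether ring size or the loss of oxygen matters more. Going by these compounds, it also remains open whether the same swap gives a similar step on the core of compound 1, which lacks the methyl.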